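From 4-methylphenyl to 3-nitrophenyl on the shared core

The source may hold more compounds than are shown below. What is called first, only, known or untested is meant among the compounds shown, and "the series" means these compounds.

In a functional assay on K562/A02 cells (Homo sapiens) for antiproliferative activity, read by MTT assay (on this read-out lower numbers stand for stronger inhibition and higher numbers for weaker inhibition), compound 1 `O=C(CCCCCNC(=S)N/N=C(\c1ccccc1)c1ccccn1)NO` gives 2030 nM and compound 2 `Cc1ccc(/C(=N/NC(=S)NCCCCCC(=O)NO)c2ccccc2)cc1` gives 3150 nM and so stands within the scatter of compound 1. Compound 3 `O=C(CCCCCNC(=S)N/N=C(\c1ccccc1)c1cccc([N+](=O)[O-])c1)NO` differs from compound 2 as follows: 3-nitrophenyl in place of 4-methylphenyl on a carbon with a double bond to nitrogen with 3-nitrophenyl in place of 4-methylphenyl on a carbon with a double bond to nitrogen. Among the compounds with values here, the only measured step at this place is a 1.6-fold higher number from compound 1 to compound 2 (0.19 log units; within the scatter) and it involves a different pair of groups. No step beyond the scatter is therefore expected in this assay and no direction is favoured. The estimated step is a 1.2-fold lower number from compound 2 to compound 3 (0.08 log units; within the scatter) and stays small. Compound 3 is estimated at 2600 nM with an expected range of 1100 nM to 6000 nM for the coming measurement.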

Compound 3, half-maximal inhibitory concentration: 940 nM
Estimate against measurement, compound 3: 2.8-fold (0.44 log units) above; the measured number lies below the stated range.
By their numbers in this assay, from the lowest: compound 3; then compounds 1 and 2 (each within the scatter of the next).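

In this assay the group on a carbon with a double bond to nitrogen now moves the number beyond the scatter: 3-nitrophenyl in place of 4-methylphenyl gives a 3.4-fold lower number from compound 2 to compound 3 (0.53 log units; beyond the scatter) and so stands apart from the earlier pair. Replacing pyridin-2-yl with 3-nitrophenyl gives a 2.2-fold lower number from compound 1 to compound 3 (0.33 log units; beyond the scatter) in the same direction. Nothing at hand gives a reason for these steps.

Still open, from the compounds shown here alone, is whether an amine or a carboxylic acid in place of the nitro group on this phenyl ring would keep the lower number.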